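A few compounds are considered here, and "the series" means these few. Any claim that something is new, unique, unknown or untested is made for them only; others in the source may bear on it.

Compound 1, with the structure `Nc1cc(N)c2nc(-c3ccccc3)c(Oc3ccc(Cl)c(Cl)c3)nc2c1`, is one of two compounds examined in a functional assay on NCI-H522 cells (Homo sapiens) for inhibition, read by sulforhodamine B assay, with a stated time of 48 h; on this read-out lower numbers stand for stronger inhibition of growth and higher numbers for weaker inhibition of growth. In this assay, within the data shown here, compound 1 gives 33900 nM, the only plain number among the two values shown. Compound 2, with the structure `CCOC(=O)[C@H](CCC(=O)O)NC(=O)c1ccc(Oc2nc3cc(N)cc(N)c3nc2-c2ccccc2)cc1`, returns in this assay only a limit of the assay, < 100000 nM, and not a number. Among the measured compounds shown here, that single limit is what the limit of < 100000 nM in this assay, at which 1 of the 2 values shown sits, describes, so compound 1 stands alone as the one compound with a definite value, and no step between measured compounds can be drawn from these two.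

Compound 3, with the structure `Nc1cc(N)c2nc(-c3ccccc3)c(Sc3ccc(F)cc3)nc2c1`, is not yet measured. It differs from compound 1 by (4-fluorophenyl)sulfanyl in place of 3,4-dichlorophenoxy on an aromatic carbon. For the measured compounds named here, since no measured step involves this kind of exchange at this position, there is no basis for expecting a change beyond the usual scatter in either direction; the step from compound 1 to compound 3 is estimated to be small, a 1.2-fold higher number from compound 1 to compound 3 (0.07 log units; within the scatter). Compound 3 is therefore expected to give 40000 nM in this assay, within a range from 10000 nM to 100000 nM.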

Compound 3, concentration for total growth inhibition: < 100000 nM
Compound 3 ended at the assay's limit; the forecaster's own chance of this, stated with the estimate: 25%; the middle value does not contradict the limit.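

In this assay, among these compounds, compound 3 gives < 100000 nM as a limit of the assay and not a number, so no step from compound 1 to compound 3 can be read. The compounds shown leave open whether (4-fluorophenyl)sulfanyl in place of 3,4-dichlorophenoxy on an aromatic carbon changes growth inhibition at all, and in which direction.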